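Naphthyl acrylamides: swapping the benzyl substituent

A few compounds are considered here, and "the series" means these few. Any claim that something is new, unique, unknown or untested is made for them only; others in the source may bear on it.

Working notes on a small set of acrylamide nitriles tested in a functional assay on SMA cells (Homo sapiens) for inhibition, read by MTT assay, with a stated time of 72 h; a lower number here means a stronger inhibitor of growth, a higher number a weaker inhibitor of growth. Within the data shown here, compound 1 `COc1ccc(CNC(=O)/C(C#N)=C/c2ccc3ccccc3c2)cc1` carries a 4-methoxyphenyl group on the benzylic carbon and gives 43000 nM in this assay; it is the only numbered value in the set. Compound 2 `COc1ccc(/C=C(\C#N)C(=O)NCc2ccc(Cl)c(Cl)c2)cc1` reaches only the limit of the assay, > 100000 nM, so its growth inhibition is not resolved; this is the point recorded as the limit of > 100000 nM in this assay, at which 1 of the 2 values shown sits. Compound 3 `N#C/C(=C\c1ccc2ccccc2c1)C(=O)NCc1ccc(Cl)c(Cl)c1` is not yet measured and differs from compound 1 by 3,4-dichlorophenyl in place of 4-methoxyphenyl on a saturated chain carbon bound to an amide-type nitrogen. Among the measured compounds shown here, no measured step follows this change, so no measured size is available. The expectation is a modest step from compound 1 to compound 3 of a 1.3-fold higher number from compound 1 to compound 3 (0.11 log units; within the scatter), toward weaker inhibition, within or just beyond the scatter. Compound 3 is therefore expected to show around 55000 nM, between 15000 nM and 150000 nM, with a real chance that only a limit is returned.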

Compound 3, concentration for 50% growth inhibition: 64000 nM
The estimate for compound 3 lay 1.2-fold (0.07 log units) below the measured number; measured number inside the range.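

In this assay, 3,4-dichlorophenyl in place of 4-methoxyphenyl on a saturated chain carbon bound to an amide-type nitrogen gives a 1.5-fold higher number from compound 1 to compound 3 (0.17 log units; within the scatter), so on this core the two groups are not told apart, although the count of hydrogen-bond acceptors goes from 1 in the leaving group to 0 in the entering one. Compound 3 returns a resolved number with 3,4-dichlorophenyl in place, so this group does not by itself rule out a measurable value. Compound 2 carries the same group and remains a limit, not a number: the limit of > 100000 nM in this assay, at which 1 of the 3 values shown sits.

Any step to or from compound 2 cannot be read, so the part played by the other end of the core stays unsized. As far as these compounds go, whether an amine, a carboxylic acid or a longer chain in place of 4-methoxyphenyl would move the number beyond the scatter also remains open.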